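The compounds below may be only part of what the source reports. "The series", "measured", "known", "first", "only" and "open" are said of these compounds alone.

Compound 1 `CN(C(=O)NC(=O)c1cccc(C(F)(F)F)c1)c1nc(C(F)(F)F)c(C(=O)N/N=C/c2cccc(C(F)(F)F)c2)s1` is one of three compounds tested in a functional assay on HeLa cells (Homo sapiens) for inhibition, read by MTT assay, with a stated time of 72 h; a lower number here means a stronger inhibitor, a higher number a weaker inhibitor. In this assay compound 1 gives 4.81 ug/mL, the lowest of the two numbers reported. Compound 2 `CN(C(=O)NC(=O)c1cccc(C(F)(F)F)c1)c1nc(C(F)(F)F)c(C(=O)N/N=C/c2ccccc2C(F)(F)F)s1` gives 7.37 ug/mL; the step of a 1.5-fold higher number from compound 1 to compound 2 (0.19 log units; within the scatter) swaps the aryl group on a carbon with a double bond to nitrogen. Compound 3 `CNc1nc(C)c(C(=O)N/N=C/c2ccc(C(F)(F)F)cc2)s1` sits at the limit of > 100 ug/mL in this assay, at which 1 of the 3 values shown sits. For compound 3 the value > 100 ug/mL is a limit of this assay and not a number. Compound 4 `CN(C(=O)NC(=O)c1ccc(Cl)cc1Cl)c1nc(C(F)(F)F)c(C(=O)N/N=C/c2cccc(C(F)(F)F)c2)s1` is not yet measured; it differs from compound 1 by 2,4-dichlorophenyl in place of 3-(trifluoromethyl)phenyl on a carbonyl carbon. Within the data shown here, no measured step touches this carbonyl position, and the single measured step on another part of the molecule stayed within the scatter, so no step beyond the scatter is expected. Compound 4 is estimated at 5.5 ug/mL, between 2 ug/mL and 15 ug/mL. The expected step is a 1.1-fold higher number from compound 1 to compound 4 (0.06 log units; within the scatter).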

Compound 4, half-maximal inhibitory concentration: 9.6 ug/mL
Beside the measured number, compound 4's estimate is 1.7-fold (0.24 log units) below it, within the range that was stated.
By their numbers in this assay, from the lowest: compounds 1, 2 and 4 (each within the scatter of the next). At a limit, above all of these: compound 3.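

Among these compounds, the carbonyl carbon now has a measured change for the first time: in this assay, 2,4-dichlorophenyl in place of 3-(trifluoromethyl)phenyl gives a 2.0-fold higher number from compound 1 to compound 4 (0.30 log units; within the scatter). At this position, then, a phenyl ring carrying chlorine and one carrying trifluoromethyl cannot be told apart in this measurement. Nothing shown here offers a measured reason for this. Whether the position holds up with other groups stays open: both groups compared are substituted phenyl rings, so an amine or a carboxylic acid on that ring, or a longer chain on the carbonyl carbon, remains untested in the compounds shown.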